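The source may report more compounds than this note shows. Statements on the series, on what has been measured and on what is new or still open speak of the compounds shown alone.

In a functional assay on NCI-H460 cells (Homo sapiens) for cytotoxicity, read by MTT assay (a higher number here means a weaker inhibitor, a lower number a stronger inhibitor), compound 2 `COc1cccc(/C=C/C(=O)c2sc(Nc3ccc(C)cc3)nc2C)c1` gives only a limit of > 25000 nM and no number. Compound 1 `COc1cccc(/C=C/C(=O)c2sc(Nc3cccc(C)c3)nc2C)c1` likewise gives only a limit of > 25000 nM in this assay and no number. The step that the two limits leave unreadable from compound 1 to compound 2 therefore cannot be read, both values sitting at the limit of > 25000 nM in this assay, at which 2 of the 2 values shown sit, in this assay. Compound 3 `COc1cccc(/C=C/C(=O)c2sc(Nc3ccc(Cl)c(Cl)c3)nc2C)c1` carries 3,4-dichlorophenyl in place of 4-methylphenyl on a nitrogen on an aromatic ring relative to compound 2. Among the compounds with values here, no measured step bears on this change, and compound 2 itself rests at a limit, so the step is expected as a step that the limit leaves unreadable from compound 2 to compound 3 with no supported direction. Compound 3 is estimated at 30000 nM in this assay, within 4000 nM to 150000 nM, and most likely reported again only as a limit.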

Compound 3, half-maximal inhibitory concentration: 20100 nM
Estimate against measurement, compound 3: 1.5-fold (0.17 log units) above; low and high end bracket the measured number.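

In this assay, within the data shown here, 3,4-dichlorophenyl on a nitrogen on an aromatic ring gives the only value shown that is a number and not a limit, with an at least 1.2-fold lower number from compound 2 to compound 3 (0.09 log units; that floor lies within the scatter) and an at least 1.2-fold lower number from compound 1 to compound 3 (0.09 log units; that floor lies within the scatter). Among these compounds, both steps are floors, so their true size stays unknown, and they show only that a group at this place can bring the value into readable range. Compound 1 and compound 2 remain limits: the limit of > 25000 nM in this assay, at which 2 of the 3 values shown sit.

On these data alone, whether both chlorines are needed stays open. So does how 4-chlorophenyl, 4-methoxyphenyl or 4-trifluoromethylphenyl would read at this place.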